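The source may hold more compounds than are shown below. What is called first, only, known or untested is meant among the compounds shown, and "the series" means these compounds.

Three compounds have been measured in a functional assay on Hep cells (Homo sapiens) for cytotoxicity, read by sulforhodamine B assay, with a stated time of 48 h (a higher number here means a weaker inhibitor, a lower number a stronger inhibitor), so far:

- compound 1 `O=C(c1cccnc1)c1cc(F)ccc1O` gives 12000 nM
- compound 2 `O=C(c1cccnc1)c1ccccc1O` gives 31000 nM
- compound 3 `C=CCOc1ccc(C)cc1C(=O)c1cccnc1` gives 72000 nM

Compound 3 has the highest number of the three and is therefore the weakest inhibitor in this set. Its value lies above those of compounds 1 and 2, and both gaps are beyond the usual scatter.

The next compound is compound 4 `Cc1ccc(O)c(C(=O)c2cccnc2)c1` and it differs from compound 3 by hydrogen in place of allyl on an oxygen on an aromatic ring in a single place. In words, this is hydrogen in place of allyl on an oxygen on an aromatic ring, or allyloxy to hydroxy.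

Going by the values given here, no measured pair makes exactly this change. Among the compounds with values here, the one measured single change, a 2.6-fold higher number from compound 1 to compound 2 (0.41 log units; beyond the scatter) as hydrogen replaces fluoro on an aromatic carbon, is only indirect evidence, and it suggests a modest step. Compounds 1 and 2 both carry the hydroxy group, and compound 2 at 31000 nM and compound 1 at 12000 nM both sit lower than compound 3. A modest fall in the number is therefore expected. The estimated change is a 2.9-fold lower number from compound 3 to compound 4 (0.46 log units; beyond the scatter) and would make compound 4 a somewhat stronger inhibitor. For compound 4 the estimate is 25000 nM with an expected range of 10000 nM to 60000 nM in this assay once it is measured.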

Compound 4, half-maximal inhibitory concentration: 11000 nM
The estimate for compound 4 lay 2.3-fold (0.36 log units) above the measured number; measured number inside the range.
By their numbers in this assay, from the lowest: compounds 4 and 1 (each within the scatter of the next); then compound 2; then compound 3.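

Read in this assay, replacing allyl with hydrogen on the oxygen on the aromatic ring gives a 6.5-fold lower number from compound 3 to compound 4 (0.82 log units; beyond the scatter) and is the first direct reading of allyloxy to hydroxy, showing that the group on this oxygen can shift the number beyond the scatter. The new compound also gives a second and third comparison at the aromatic carbon that carries fluoro in compound 1: methyl in place of hydrogen gives a 2.8-fold lower number from compound 2 to compound 4 (0.45 log units; beyond the scatter) as a step beyond the scatter, while methyl in place of fluoro gives a 1.1-fold lower number from compound 1 to compound 4 (0.04 log units; within the scatter) as a step within it, so methyl and fluoro cannot be told apart here, and each stands apart from hydrogen. No measurement shown explains the size of any of these steps.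

The compounds shown leave open whether a plain methyl or a longer chain on that oxygen would give a number closer to that of compound 3 or that of compound 4, as allyl and hydrogen are the only groups seen there. They also leave open how a chloro group or an amine on the aromatic carbon would compare with methyl and fluoro.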